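The source may hold more compounds than are shown below. What is called first, only, known or untested is meant among the compounds shown, and "the series" means these compounds.

Of the compounds shown here, three built on one shared core have been measured so far. Compound 1 `Cc1ccc(-c2cc(OCCCCC(C)(C)C(=O)O)nc3ccccc23)cc1`, whose outer ring carries a methyl group, gives 30 nM in an assay on membranes from spleen (Cavia porcellus) for binding affinity to leukotriene B4 receptor 1 (Homo sapiens); on this read-out higher numbers stand for weaker inhibition and lower numbers for stronger inhibition. Compound 2 `CC(C)(CCCCOc1cc(-c2ccc([N+](=O)[O-])cc2)c2ccccc2n1)C(=O)O`, carrying a nitro group in its place, gives 150 nM in this assay; a 5.0-fold higher number from compound 1 to compound 2 (0.70 log units; beyond the scatter). Compound 3 `COc1cccc(-c2cc(OCCCCC(C)(C)C(=O)O)nc3ccccc23)c1`, which carries a 3-methoxyphenyl group, gives 300 nM in this assay, the highest number of the three: a 10-fold higher number from compound 1 to compound 3 (1.00 log units; beyond the scatter), whereas a 2.0-fold higher number from compound 2 to compound 3 (0.30 log units; within the scatter).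

The next compound, compound 4 `CC(C)(CCCCOc1cc(-c2cccc(Cl)c2)c2ccccc2n1)C(=O)O`, differs from compound 3 in one place: chloro in place of methoxy on an aromatic carbon. Within the data shown here, only two of the measured steps touch the outer ring at all, a 10-fold higher number from compound 1 to compound 3 (1.00 log units; beyond the scatter) and a 2.0-fold higher number from compound 2 to compound 3 (0.30 log units; within the scatter), and both change the kind of group together with where it sits, so neither reads directly on a swap of methoxy for chloro at one fixed place. Among the measured compounds shown here, there is thus no measured step that would point to a large move in either direction. The step from compound 3 to compound 4 is expected to be a 1.5-fold lower number from compound 3 to compound 4 (0.18 log units; within the scatter), which is not beyond the scatter. Compound 4 is therefore estimated at 200 nM in this assay, with a range from 60 nM to 700 nM.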

Compound 4, half-maximal inhibitory concentration: 1100 nM
Beside the measured number, compound 4's estimate is 5.5-fold (0.74 log units) below it, and the stated range ends below it.
By their numbers in this assay, from the lowest: compound 1; then compounds 2 and 3 (each within the scatter of the next); then compound 4.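

Among these compounds, the swap of methoxy for chloro is the first step here that changes the group while its place on the outer ring stays fixed, and in this assay it is not neutral: a 3.7-fold higher number from compound 3 to compound 4 (0.56 log units; beyond the scatter). Compound 4 now has the highest number of the series, with a 7.3-fold higher number from compound 2 to compound 4 (0.87 log units; beyond the scatter) and a 37-fold higher number from compound 1 to compound 4 (1.56 log units; beyond the scatter), although these two longer steps change the kind of group and its place together, so neither can be credited to the chloro alone. What lies behind the loss on going from methoxy to chloro stays unexplained, as no supporting measurement is available for it.

It remains open how much of the large gap to compound 1 comes from the group and how much from where it sits, as none of the compounds shown carries the same group at two places on the outer ring. Also open, from the compounds shown here alone, is how other groups at this same place would read, such as an amine or a hydroxyl, and so whether methoxy is unusually well tolerated there or chloro unusually poorly.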